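Methoxy for Bromo: What the Next Number Should Look Like

The source may hold more compounds than are shown below. What is called first, only, known or untested is meant among the compounds shown, and "the series" means these compounds.

Of the compounds shown here, three sharing one core have been measured in a functional assay on HepG2 cells (Homo sapiens) for inhibition, read by MTT assay, with a stated time of 48 h, tested at 10 uM; a higher number here means more inhibition of growth at the concentration tested, a lower number less inhibition of growth. Compound 1 `O=C(/C=C/c1ccc(OCc2cn(Cc3ccccc3Br)nn2)cc1)c1ccc(Br)cc1` gives 34%. Compound 2 `O=C(/C=C/c1ccc(OCc2cn(Cc3ccc(Br)cc3)nn2)cc1)c1ccc(Br)cc1` gives 22%, and compound 3 `O=C(/C=C/c1ccc(OCc2cn(Cc3ccccc3F)nn2)cc1)c1ccc(Br)cc1` gives 29%. Among these, compound 1 carries the largest number: the step of a number 12 percentage points lower from compound 1 to compound 2 (beyond the scatter) lies beyond the scatter, whereas the step of a number 5 percentage points lower from compound 1 to compound 3 (within the scatter) does not, so compound 1 and compound 3 cannot be told apart, and the step of a number 7 percentage points higher from compound 2 to compound 3 (within the scatter) likewise stays within the scatter.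

Compound 4 `COc1ccc(C(=O)/C=C/c2ccc(OCc3cn(Cc4ccccc4Br)nn3)cc2)cc1` has not yet been measured. It differs from compound 1 in one place: methoxy in place of bromo on an aromatic carbon. All three measured steps concern the group on the saturated chain carbon bound to an aromatic nitrogen, far from where compound 4 is altered, so none of them speaks directly to this change. The closest analogy, a swap of one halogen for another on an aromatic carbon, produced only the within-scatter step from compound 1 to compound 3. For the measured compounds named here, with no measured step bearing on this position, the expectation is a step of a number 4 percentage points lower from compound 1 to compound 4 (within the scatter), that is, nothing beyond the scatter. Compound 4 is therefore estimated at 30%, with a range from 15% to 45%.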

Compound 4, percent growth inhibition at one concentration: 44%
Beside the measured number, compound 4's estimate is 14 percentage points below it; the measured number falls inside the stated range.
By their numbers in this assay, from the lowest: compounds 2, 3, 1 and 4 (each within the scatter of the next, the first and the last beyond it).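

For the compounds shown here, compound 4 gives the first reading of a change at the aromatic carbon that carries bromo in compound 1; all the earlier steps concerned the group on the saturated chain carbon bound to an aromatic nitrogen. In this assay, going from 4-bromophenyl to 4-methoxyphenyl gives a number 10 percentage points higher from compound 1 to compound 4 (within the scatter) and so shows that this position accepts methoxy in place of bromo without a change that can be told from the scatter, even though one heavy atom leaves, two enter and a hydrogen-bond acceptor is added. No outside evidence bears on what lies behind this step.

On these data alone, a single swap at this position cannot show whether the group here matters at all, so it remains open whether a more different group on the same aromatic carbon, such as a carboxylic acid or a dimethylamino group, would move the number beyond the scatter. As far as these compounds go, it is also open whether methoxy in place of bromo would give a similar step on compound 2 or compound 3, whose other end differs from that of compound 1.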